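Three Compounds, One Value, and an Expected Fourth

The compounds below may be only part of what the source reports. "The series", "measured", "known", "first", "only" and "open" are said of these compounds alone.

Measured compounds:
- compound 1 `CC(C)(C)C1=NN(c2ccccc2Cl)C(c2ccc(O)cc2)C1`: "not determined" (no result reported)
- compound 2 `CC(C)(C)C1=NN(c2ccccc2F)C(c2ccc(O)cc2)C1`: "not determined" (no result reported)
- compound 3 `Oc1ccc(C2CC(c3ccccc3O)=NN2c2ccc(Cl)cc2)cc1`: 1500 nM

The assay used is an assay on isolated protein for inhibition of protein kinase C zeta type (Homo sapiens), with a stated time of 4 min; on this read-out higher numbers stand for weaker inhibition and lower numbers for stronger inhibition. In this assay compound 1 gives "not determined" (no result reported), and compound 2 gives "not determined" (no result reported), so for neither of them is a number given. Within the data shown here, compound 3 therefore stands alone: in this assay compound 3 gives 1500 nM, and it is the only value against which anything else can be set. Among the measured compounds shown here, with no second number, no step between measured compounds exists, and no trend within the set can be claimed.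

Compound 4 `Nc1ccc(C2=NN(c3ccc(Cl)cc3)C(c3ccc(O)cc3)C2)cc1` has not yet been measured. It differs from compound 3 in a single place: 4-aminophenyl in place of 2-hydroxyphenyl on a carbon with a double bond to nitrogen. For the measured compounds named here, nothing among the measured compounds speaks to the effect of this exchange, so the expectation rests on compound 3 alone. The step from compound 3 to compound 4 is expected to be no change at the digits printed from compound 3 to compound 4 (within the scatter), that is, no change beyond the usual scatter in either direction. Going by the values given here, on that basis compound 4 is estimated to give 1500 nM in this assay, with a range from 400 nM to 6000 nM reflecting how little the single value of compound 3 can anchor.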

Compound 4, half-maximal inhibitory concentration: 5400 nM
Beside the measured number, compound 4's estimate is 3.6-fold (0.56 log units) below it; low and high end bracket the measured number.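

In this assay, among these compounds, placing 4-aminophenyl instead of 2-hydroxyphenyl on the carbon with a double bond to nitrogen gives a 3.6-fold higher number from compound 3 to compound 4 (0.56 log units; beyond the scatter), a modest loss of inhibition that lies beyond the usual scatter and is the first change in the set that can be read at all. It shows that this position responds to the identity of its aromatic group, even though the leaving and entering groups match in every count available, including heavy atoms, hydrogen-bond donors and hydrogen-bond acceptors, so those counts do not separate the two; it also shows that inhibition is weakened here rather than lost, since compound 4 still gives a number. Nothing shown here bears on why the number rises.

This single step changes both the atom that carries the hydrogen-bond donor and where it stands on the phenyl ring, so it cannot say which of the two matters, and 4-hydroxyphenyl at this same carbon would be needed to pull them apart. Going by these compounds, how this position would respond to an unsubstituted phenyl, a methoxy group or a carboxylic acid on the ring also remains open.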